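Swapping an imidazole for a fluoropyridine: expected solubility

A few compounds are considered here, and "the series" means these few. Any claim that something is new, unique, unknown or untested is made for them only; others in the source may bear on it.

Measured compounds:
compound 1 `Cc1cc(NCc2cnccn2)n2nc(C)c(-c3ccccc3)c2n1` gives 7100 nM in a physicochemical assay for solubility, read by HPLC, using the shake flask method, measured as kinetic solubility, with a stated time of 2 h, at pH 7.4; a lower number here means a less soluble compound, a higher number a more soluble compound
compound 2 `Cc1cc(OCc2ccccn2)n2nc(C)c(-c3ccccc3)c2n1` gives 25600 nM in this assay
compound 3 `Cc1cc(NCc2c[nH]cn2)n2nc(C)c(-c3ccccc3)c2n1` gives 14600 nM in this assay

Compound 3 stands second highest of the three numbers in this assay: it sits within the scatter of compound 2, and the step of a 2.1-fold higher number from compound 1 to compound 3 (0.31 log units; beyond the scatter) is the only one that separates it from a neighbour beyond the scatter. Compound 4 `Cc1cc(NCc2ccc(F)cn2)n2nc(C)c(-c3ccccc3)c2n1` is not yet measured. It differs from compound 3 in one place: 5-fluoropyridin-2-yl in place of 1H-imidazol-4-yl on a saturated chain carbon bound to a nitrogen on an aromatic ring. Of the measured steps, the one that bears most directly on this change is a 2.1-fold higher number from compound 1 to compound 3 (0.31 log units; beyond the scatter), where a six-membered ring with two nitrogens gave way to the imidazole; compound 4 moves in the opposite direction, from the imidazole back to a six-membered ring carrying one nitrogen and a fluorine. The step of a 1.8-fold lower number from compound 2 to compound 3 (0.24 log units; within the scatter) changes both linker and ring at once and is within the scatter, so it gives little guidance. A modest fall in solubility is therefore expected, roughly a 2.1-fold lower number from compound 3 to compound 4 (0.32 log units; beyond the scatter) in this assay. Compound 4 is estimated at 7000 nM, with a range from 2500 nM to 20000 nM.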

Compound 4, solubility: < 5000 nM
Compound 4 was reported as a limit (the forecaster's own chance of this, stated with the estimate: 10%); middle value at least 1.4-fold (0.14 log units) away from the limit.
By their numbers in this assay, from the lowest: compound 1; then compounds 3 and 2 (each within the scatter of the next). At a limit, below all of these: compound 4.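

Compound 4 is reported only as a limit in this assay: the limit of < 5000 nM in this assay, at which 1 of the 4 values shown sits. Even so, placing 5-fluoropyridin-2-yl instead of 1H-imidazol-4-yl on the saturated chain carbon gives an at least 2.9-fold lower number from compound 3 to compound 4 (0.46 log units; beyond the scatter), so a second six-membered ring on this amino chain, after the pyrazin-2-yl of compound 1, reads lower than the imidazole of compound 3. The two six-membered rings are not cleanly separated, however, since the comparison between them is an at least 1.4-fold lower number from compound 1 to compound 4 (0.15 log units; that floor lies within the scatter).

The compounds shown cannot tell whether the fluorine or the loss of the imidazole's hydrogen-bond donor goes with this drop. On these data alone, what a plain pyridin-2-yl on the same amino chain would give also remains open, as does the effect of a morpholine or a carboxylic acid on that ring.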